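The source may hold more compounds than are shown below. What is called first, only, known or untested is meant among the compounds shown, and "the series" means these compounds.

Working notes on the glycinamide pair across two cores. Compound 1 `COc1ccc(C(=O)c2ccc(OC)c3c2C=CC(C)(C)O3)c(NC(=O)CN)c1` gives 890 nM in a functional assay on A2780 cells (Homo sapiens) for antiproliferative activity, read by MTT assay, with a stated time of 48 h; on this read-out higher numbers stand for weaker inhibition and lower numbers for stronger inhibition. Compound 2 `COc1ccc(C(=O)c2ccc(OC)c3c2C=CC(C)(C)O3)c(NC(=O)CN(C)C)c1` gives 3990 nM in this assay. The two share a core and differ only by amino in place of dimethylamino on a saturated chain carbon bound to a carbonyl carbon; this change gives a 4.5-fold lower number from compound 2 to compound 1 (0.65 log units; beyond the scatter). Compound 3 `COc1ccc(C(=O)c2cc(OC)c(OC)c(OC)c2)c(NC(=O)CN(C)C)c1` is built on a different core and gives 580 nM in this assay; its number stands within the scatter of compound 1 and beyond the scatter of compound 2. The difference between the core of compound 3 and the core of compound 2 is not broken down here.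

Compound 4 `COc1ccc(C(=O)c2cc(OC)c(OC)c(OC)c2)c(NC(=O)CN)c1` is not yet measured. It differs from compound 3 by amino in place of dimethylamino on a saturated chain carbon bound to a carbonyl carbon, the same change as made from compound 2 to compound 1, at the same place. The step of a 2.9-fold lower number from compound 3 to compound 4 (0.46 log units; beyond the scatter) is expected in this assay because a 4.5-fold lower number from compound 2 to compound 1 (0.65 log units; beyond the scatter) was seen on the other core; as that step rests on one pair on one core, a somewhat smaller transfer is allowed for. Compound 4 is therefore estimated at 200 nM in this assay, between 60 nM and 700 nM.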

Compound 4, half-maximal inhibitory concentration: 190 nM
Compound 4: the middle estimate sits 1.1-fold (0.02 log units) above what was measured, and the stated range covers the measured number.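

In this assay the change from dimethylamino to amino again lowers the number, with a 3.1-fold lower number from compound 3 to compound 4 (0.48 log units; beyond the scatter), so the direction seen on the core of compound 1 also holds on the core of compound 4. The two steps cannot be told apart in size: the same change on two cores in this assay, a 4.5-fold lower number (0.65 log units; beyond the scatter) from compound 2 to compound 1 and a 3.1-fold lower number (0.48 log units; beyond the scatter) from compound 3 to compound 4, 1.5-fold (0.17 log units) apart, within the scatter of two such steps. Among these compounds, this rests on only two pairs on two cores, in one cell line and with one read-out, so it supports carrying the change between these two cores but does not explain the step or extend it to any further core.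

Still open, from the compounds shown here alone, is how the number responds to other groups in this place on a saturated chain carbon bound to a carbonyl carbon, such as methylamino, a cyclic amine like morpholine or piperidine, or a carboxylic acid, and whether a longer chain carrying the amino group keeps the step. Also open is which part of the difference in core matters, as the compounds shown do not break it down.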